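Methyl for methoxy in a long-lived compound

A few compounds are considered here, and "the series" means these few. Any claim that something is new, unique, unknown or untested is made for them only; others in the source may bear on it.

Measured in an ADME assay for pharmacokinetics, at pH 7.4; on this read-out lower numbers stand for a shorter-lived compound and higher numbers for a longer-lived compound:
compound 1 `COc1c(C)cnc(C[S+]([O-])c2nc3cc(OC(F)F)ccc3[nH]2)c1C` gives 15 h
compound 2 `COc1ccnc(C[S+]([O-])c2nc3cc(F)c(OC(F)F)cc3[nH]2)c1OC` gives 150 h

Compound 2 at 150 h stands highest of the two, and compound 1 at 15 h lies below it by a gap beyond the scatter. These two compounds differ in more than one place, so no measured single change is available as a guide.

Compound 3 `COc1ccnc(C[S+]([O-])c2nc3cc(F)c(OC(F)F)cc3[nH]2)c1C` differs from compound 2 by methyl in place of methoxy on an aromatic carbon. Compound 1 at 15 h also carries methyl on an aromatic carbon, which gives a loose hint of a lower number in this assay. A moderate fall, somewhat beyond the scatter, is expected, and the estimated change is a 2.5-fold lower number from compound 2 to compound 3 (0.40 log units; beyond the scatter). The expected value for compound 3 is 60 h, with an estimated range of 20 h to 150 h.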

Compound 3, half-life: 4 h
For compound 3 the middle estimate is 15-fold (1.18 log units) above the measured one, outside the stated range (below it).
By their numbers in this assay, from the lowest: compound 3; then compound 1; then compound 2.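

In this assay, for the compounds shown here, the first single change that can be read is methyl in place of methoxy on an aromatic carbon, two atoms from the ring nitrogen, and it gives a 38-fold lower number from compound 2 to compound 3 (1.57 log units; beyond the scatter), a large step. With everything else in compound 2 held fixed, the half-life therefore depends strongly on which of these two groups occupies this position, a dependence that the multiple differences between compound 1 and compound 2 could not isolate. No measurement at hand accounts for the size of this step.

From the compounds shown here alone, it remains open whether ethoxy, a plain hydrogen, chlorine or an amine at this position would keep the half-life of compound 2 or follow compound 3. Also open, going by these compounds, is whether the same change gives a step of similar size when the fluorine on the shared core is absent.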